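The source may report more compounds than this note shows. Statements on the series, on what has been measured and on what is new or still open speak of the compounds shown alone.

Working notes on the series. In an assay on cells for inhibition of sodium/hydrogen exchanger (Oryctolagus cuniculus) (a higher number here means a weaker inhibitor, a lower number a stronger inhibitor), compound 1 `Cc1cc2c(cc1C(=O)N=C(N)N)S(=O)(=O)CC2C(C)C` gives 21 nM. Compound 2 `CCC1(O)CS(=O)(=O)c2cc(C(=O)N=C(N)N)c(C)cc21` gives 34 nM in this assay, and compound 3 `Cc1cc2c(cc1C(=O)N=C(N)N)S(=O)(=O)CC2(O)C(=O)c1ccccc1` gives 43 nM in this assay. Compound 2 thus holds the second highest of the three numbers; its nearest neighbour is compound 3, and the gap to compound 1 is within the scatter as well, so these three numbers do not order the compounds.

Within the data shown here, the one single-change step measured so far is a 1.3-fold higher number from compound 2 to compound 3 (0.10 log units; within the scatter), a benzoyl in place of ethyl on a saturated ring carbon, and it stays within the scatter.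

Compound 4 `CCC1CS(=O)(=O)c2cc(C(=O)N=C(N)N)c(C)cc21` differs from compound 2 by hydrogen in place of hydroxy on a saturated ring carbon. Among the measured compounds shown here, no measured step removes a hydroxy at that carbon. Compound 1 also lacks the hydroxy but carries a different group at that carbon, so it is not a clean comparison; still, the numbers for compound 1 and compound 2 lie within the scatter of each other. For the measured compounds named here, the only measured step concerns a different group and is small, so the hydroxy removal is expected to give a step of a 1.4-fold lower number from compound 2 to compound 4 (0.13 log units; within the scatter) in this assay, nothing beyond the scatter, with a slight lean toward a lower number suggested by hydroxy-free compound 1 at 21 nM. Compound 4 is estimated at 25 nM in this assay, with a range of 10 nM to 60 nM.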

Compound 4, half-maximal inhibitory concentration: 24 nM
For compound 4 the middle estimate is 1.0-fold (0.02 log units) above the measured one; low and high end bracket the measured number.
By their numbers in this assay, from the lowest: compounds 1, 4, 2 and 3 (each within the scatter of the next, the first and the last beyond it).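

In this assay, among these compounds, the step of a 1.4-fold lower number from compound 2 to compound 4 (0.15 log units; within the scatter) gives the first direct reading of this change: the hydroxy on the saturated ring carbon, two ring bonds from the ring sulfur, can give way to hydrogen with no step beyond the scatter, while ethyl stays in place. The step of a 1.1-fold higher number from compound 1 to compound 4 (0.06 log units; within the scatter) adds a second reading at the same ring carbon, where hydrogen replaces methyl on a saturated chain carbon bound to a saturated chain carbon and a saturated ring carbon, and it too stays within the scatter, so neither the hydroxy nor that methyl is shown here to matter for the number in this assay. No supporting measurement bears on these two results.

On these data alone, whether any single change at this ring carbon can move the number beyond the scatter stays open, since only compound 1 and compound 3 lie beyond it of each other and they differ in more than one place. As far as these compounds go, what an amine or a carboxylic acid at that ring carbon, or a longer chain in place of ethyl, would do to the number also stays open.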